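Benzyl swap on the shared core, compound 1 to compound 4

The source may report more compounds than this note shows. Statements on the series, on what has been measured and on what is new or still open speak of the compounds shown alone.

Compound 1 `Nc1cc(N)c2nc(-c3ccccc3)c(NCc3ccc(Cl)c(Cl)c3)nc2c1` carries a 3,4-dichlorobenzyl group on the shared core. In a functional assay on K562 cells (Homo sapiens) for inhibition, read by sulforhodamine B assay, with a stated time of 48 h (on this read-out lower numbers stand for higher toxicity in this test and higher numbers for lower toxicity in this test), compound 1 gives < 100000 nM, which is a limit of the assay rather than a number. Compound 3 `Nc1cc(N)c2nc(-c3ccccc3)c(Sc3ccc(Cl)c(Cl)c3)nc2c1` is a close relative with the same 3,4-dichlorophenyl group; in this assay compound 3 gives < 100000 nM, again a limit. Compound 2 `CCOC(=O)[C@H](CCC(=O)O)NC(=O)c1ccc(Sc2nc3cc(N)cc(N)c3nc2-c2ccccc2)cc1` belongs to the same core; in this assay compound 2 gives < 100000 nM, also a limit. All three measured compounds therefore sit at the limit of < 100000 nM in this assay, at which 3 of the 3 values shown sit, and compound 1 cannot be placed more precisely than that.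

Compound 4 `COc1ccc(CNc2nc3cc(N)cc(N)c3nc2-c2ccccc2)cc1` is not yet measured. Against compound 1 the change is 4-methoxyphenyl in place of 3,4-dichlorophenyl on a saturated chain carbon bound to a nitrogen on an aromatic ring. For the measured compounds named here, no step between measured compounds is available, and every value so far is a limit, so the series gives no direction to lean on. The expected step is a step that the limit leaves unreadable from compound 1 to compound 4, none beyond the scatter, with a substantial chance that the read-out is once more only a limit. Compound 4 is accordingly estimated at 40000 nM, within 8000 nM to 100000 nM.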

Compound 4, concentration lethal to 50% of the cells: < 100000 nM
Compound 4 ended at the assay's limit; the forecaster's own chance of this, stated with the estimate: 70%; the middle value is on the limit's open side.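

In this assay compound 1 and compound 4 both stand only as limits, so no step can be read between them. The compounds shown leave open how far any of them lies from that limit, and whether 4-methoxybenzyl or 3,4-dichlorobenzyl gives the lower lethal concentration.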